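This account rests on a few compounds, and the source may have more. Where it says the series, first, only, none or still open, it means among the compounds named here.

Measured in a functional assay on NCI/ADR-RES cells (Homo sapiens) for inhibition, read by sulforhodamine B assay, with a stated time of 48 h; a lower number here means a stronger inhibitor of growth, a higher number a weaker inhibitor of growth:
compound 1 `Nc1cc(N)c2nc(-c3ccccc3)c(Oc3ccc(Cl)c(Cl)c3)nc2c1` gives 36300 nM;
compound 2 `Nc1cc(N)c2nc(-c3ccccc3)c(NCc3ccc(Cl)c(Cl)c3)nc2c1` gives 45700 nM;
compound 3 `CCOC(=O)[C@H](CCC(=O)O)NC(=O)c1ccc(Sc2nc3cc(N)cc(N)c3nc2-c2ccccc2)cc1` gives < 100000 nM, which is a limit of this assay and not a number (the limit of < 100000 nM in this assay, at which 1 of the 3 values shown sits).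

Compound 1 holds the lowest of the two numbers in this assay; compound 2 sits within the scatter of it, so the two are not told apart. Compound 4 `Nc1cc(N)c2nc(-c3ccccc3)c(Oc3ccc(F)cc3)nc2c1` is not yet measured. It differs from compound 1 in one place: 4-fluorophenyl in place of 3,4-dichlorophenyl on an oxygen on an aromatic ring. For the measured compounds named here, no measured step matches this change, and the data give no property of either group. The expected step is a 1.4-fold higher number from compound 1 to compound 4 (0.14 log units; within the scatter), a shift that may not clear the scatter, with the wider uncertainty toward weaker growth inhibition. Compound 4 is estimated at 50000 nM, expected to fall between 20000 nM and 100000 nM in this assay.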

Compound 4, concentration for total growth inhibition: 36300 nM
The estimate for compound 4 lay 1.4-fold (0.14 log units) above the measured number; measured number inside the range.
By their numbers in this assay, from the lowest: compounds 1, 4 and 2 (each within the scatter of the next).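

In this assay, 4-fluorophenyl in place of 3,4-dichlorophenyl on an oxygen on an aromatic ring gives no change at the digits printed from compound 1 to compound 4 (within the scatter). For the compounds shown here, this is the first single-place change read at this oxygen, and it shows that the two chlorines are not needed to keep the growth inhibition of compound 1. Nothing in the data shown accounts for this flat step.

Still open, from the compounds shown here alone, is whether an amine or a carboxylic acid on this phenyl ring would move the number beyond the scatter. The same holds for a longer chain between the oxygen and the ring.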